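A Longer Amine-Bearing Acyl Chain for Compound 4

This account rests on a few compounds, and the source may have more. Where it says the series, first, only, none or still open, it means among the compounds named here.

Three compounds of one series were measured in an assay on L1.2 cells for binding affinity to C-C chemokine receptor type 8 (Homo sapiens); on this read-out higher numbers stand for weaker inhibition and lower numbers for stronger inhibition. Compound 1 `CCOC(=O)N1CCC(NS(=O)(=O)c2ccc(C(=O)NC3CCCCC3)c3ccccc23)CC1` gives 9.5 nM. Compound 2 `CC(=O)N1CCC(NS(=O)(=O)c2ccc(NC(=O)c3ccccc3C)c3ccccc23)CC1` gives 6.7 nM, and compound 3 `Cc1ccccc1C(=O)Nc1ccc(S(=O)(=O)NC2CCN(C(=O)CO)CC2)c2ccccc12` gives 5.4 nM. Compound 3 shows the lowest of the three numbers, yet its gaps to compound 2 and to compound 1 both lie within the scatter, so no order among them can be claimed. Going by the values given here, the only single-point step, a 1.2-fold lower number from compound 2 to compound 3 (0.09 log units; within the scatter), is also within the scatter. Compound 4 `Cc1ccccc1C(=O)Nc1ccc(S(=O)(=O)NC2CCN(C(=O)CCCN)CC2)c2ccccc12` differs from compound 3 by 2-aminoethyl in place of hydroxy on a saturated chain carbon bound to a carbonyl carbon. Because the step at this chain position, a 1.2-fold lower number from compound 2 to compound 3 (0.09 log units; within the scatter), was flat, and since varied acyl groups across compounds 1 to 3 gave values close together, another change there is expected to stay within the scatter in this assay. Compound 4 is therefore estimated at 6.5 nM, with a range from 2.5 nM to 18 nM, an expected step of a 1.2-fold higher number from compound 3 to compound 4 (0.08 log units; within the scatter).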

Compound 4, inhibition constant: 1.6 nM
Estimate against measurement, compound 4: 4.1-fold (0.61 log units) above; the measured number lies below the stated range.
By their numbers in this assay, from the lowest: compound 4; then compounds 3, 2 and 1 (each within the scatter of the next).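

In this assay the change to 2-aminoethyl from hydroxy gives a 3.4-fold lower number from compound 3 to compound 4 (0.53 log units; beyond the scatter) and the change to 2-aminoethyl from hydrogen gives a 4.2-fold lower number from compound 2 to compound 4 (0.62 log units; beyond the scatter) while hydroxy in place of hydrogen had stayed within the scatter, so this place on a saturated chain carbon bound to a carbonyl carbon does respond to substitution. Nothing available gives a cause for these steps.

The compounds shown leave open whether the amine or the longer chain carries the step. A propyl group in place of 3-aminopropyl would separate the two, and a carboxylic acid at the end of the same chain would show whether another end group does the same.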